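Cytotoxicity notes: aryl hydrazone swaps on a shared core

The source may report more compounds than this note shows. Statements on the series, on what has been measured and on what is new or still open speak of the compounds shown alone.

Measured compounds:
compound 1, `COc1ccccc1-c1nnc(-c2ccc(C(=O)N/N=C/c3ccccc3[N+](=O)[O-])cc2)o1`: 161000 nM
compound 2, `COc1ccccc1-c1nnc(-c2ccc(C(=O)N/N=C/c3c(O)cc(O)cc3O)cc2)o1`: 12400 nM

Among the measured compounds shown here, compound 2 gives the lower of the two numbers in an ADME assay on THP-1 cells (Homo sapiens) for cytotoxicity; on this read-out higher numbers stand for weaker inhibition and lower numbers for stronger inhibition; the one measured step, a 13-fold lower number from compound 1 to compound 2 (1.11 log units; beyond the scatter), shows how far one aryl swap on the carbon with a double bond to nitrogen can move this read-out. Compound 3, `COc1ccc(/C=N/NC(=O)c2ccc(-c3nnc(-c4ccccc4OC)o3)cc2)c(O)c1`, is not yet measured. It differs from compound 2 by 2-hydroxy-4-methoxyphenyl in place of 2,4,6-trihydroxyphenyl on a carbon with a double bond to nitrogen. For the measured compounds named here, no measured step bears directly on this particular exchange; the only guide is that the single aryl change recorded, from compound 1 to compound 2, was large. A step of moderate size in either direction would therefore not surprise, and the expectation leans toward a somewhat higher number than compound 2. The estimate for compound 3 is 30000 nM, within 8000 nM to 120000 nM, meaning an expected step of a 2.4-fold higher number from compound 2 to compound 3 (0.38 log units; beyond the scatter).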

Compound 3, half-maximal inhibitory concentration: 308000 nM
Compound 3: the middle estimate sits 10-fold (1.01 log units) below what was measured; the measured number lies above the stated range.
By their numbers in this assay, from the lowest: compound 2; then compounds 1 and 3 (each within the scatter of the next).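

In this assay, a 25-fold higher number from compound 2 to compound 3 (1.40 log units; beyond the scatter) shows that this position responds strongly even when one hydroxy-bearing aryl group replaces another, both with 9 heavy atoms, and so the large change is not confined to a swap away from 2-nitrophenyl. The other new comparison, a 1.9-fold higher number from compound 1 to compound 3 (0.28 log units; within the scatter), puts 2-hydroxy-4-methoxyphenyl level with 2-nitrophenyl, so among these three compounds only the 2,4,6-trihydroxyphenyl group of compound 2 stands apart on the carbon with a double bond to nitrogen. No measurement at hand accounts for this gap.

From the compounds shown here alone, it remains open whether a 2,4-dihydroxyphenyl group on that carbon would read with compound 2 or with compound 3. Also open, going by these compounds, is how an aryl group carrying an amine or a carboxylic acid would read on the shared core.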